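Halogen swap on the benzyl group of an isatin thiosemicarbazone

The source may report more compounds than this note shows. Statements on the series, on what has been measured and on what is new or still open speak of the compounds shown alone.

Measured compounds:
compound 1, `O=C1Nc2ccc(Cl)cc2/C1=N/NC(=S)Nc1ccc(Cl)cc1`, 61000 nM in a functional assay on CCRF-CEM cells (Homo sapiens), with a stated time of 72 h; on this read-out lower numbers stand for stronger inhibition and higher numbers for weaker inhibition
compound 2, `O=C1Nc2ccc(F)cc2/C1=N/NC(=S)Nc1ccc(Cl)cc1`, 25000 nM in this assay
compound 3, `Cc1ccc(NC(=S)N/N=C2\C(=O)N(Cc3ccc(F)cc3)c3ccc(Br)cc32)cc1`, 132000 nM in this assay

Compounds 1 and 2 share a core and differ in one place: chloro in place of fluoro on an aromatic carbon. The step is a 2.4-fold higher number from compound 2 to compound 1 (0.39 log units; beyond the scatter).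

Compound 3 has the highest number of the three in this assay; the gap to compound 1 and the larger gap to compound 2 both lie beyond the scatter. The difference between the core of compound 3 and the core of compound 2 is not broken down here.

Compound 4, `Cc1ccc(NC(=S)N/N=C2\C(=O)N(Cc3ccc(Cl)cc3)c3ccc(Br)cc32)cc1`, is not yet measured. It differs from compound 3 in one place: chloro in place of fluoro on an aromatic carbon. This is the same kind of change as that from compound 2 to compound 1, but not the same: there the exchange sits on a six-membered aromatic ring of carbon only that is part of a fused or bridged system of two rings, meta and para to a fused ring, whereas here it sits on a six-membered aromatic ring of carbon only, para to a large group, on a benzyl group.

Among the measured compounds shown here, for compound 4 a step of a 1.4-fold higher number from compound 3 to compound 4 (0.16 log units; within the scatter) is expected in this assay, somewhat smaller than the step from compound 2 to compound 1 because a 2.4-fold higher number from compound 2 to compound 1 (0.39 log units; beyond the scatter) was measured at a different place, and the single comparison gives only a weak lead. Compound 4 is estimated at 190000 nM, with a range from 80000 nM to 450000 nM.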

Compound 4, half-maximal inhibitory concentration: >= 500000 nM
Compound 4: a limit, no number; the forecaster's own chance of this, stated with the estimate: 30%; middle value at least 2.6-fold (0.42 log units) from the limit.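

In this assay, chloro in place of fluoro goes the same way on both cores, with a 2.4-fold higher number from compound 2 to compound 1 (0.39 log units; beyond the scatter) and an at least 3.7-fold higher number from compound 3 to compound 4 (0.57 log units; beyond the scatter). The value of >= 500000 nM for compound 4 is a limit of the assay, not a number. The direction of the change therefore carries over between these two cores, where it also sits at different places, but this is only two pairs, and whether the size carries over cannot be said: the same change on two cores in this assay, a 2.4-fold higher number (0.39 log units; beyond the scatter) from compound 2 to compound 1 and an at least 3.7-fold higher number (0.57 log units; beyond the scatter) from compound 3 to compound 4; the limit leaves it open whether they differ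

Still open, on these data alone, is what the step from 4-fluorobenzyl to 4-chlorobenzyl is worth as a number, and whether the same exchange gives a comparable step at the other place when the rest of the molecule stays the same, since the pairs here differ in both core and place. Also open, as far as these compounds go, is how a plain benzyl group, or a benzyl group carrying a methoxy group, an amine or a carboxylic acid in place of the halogen, would read in this assay, and whether any such group would bring the number down towards that of compound 2 at 25000 nM.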